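This account rests on a few compounds, and the source may have more. Where it says the series, first, only, none or still open, it means among the compounds named here.

In a functional assay on MDA-MB-231 cells (Homo sapiens) for antiproliferative activity, read by sulforhodamine B assay, with a stated time of 48 h (a higher number here means a weaker inhibitor, a lower number a stronger inhibitor), compound 1 (`COc1ccc2nc(-c3ccc(N/C=C\C(=O)c4cc(OC)c(OC)c(OC)c4)c(C)c3)sc2c1`) gives 17000 nM and compound 2 (`COc1ccc2nc(-c3ccc(N/C=C\C(=O)c4ccc(OC)c([N+](=O)[O-])c4)c(C)c3)sc2c1`) gives 17600 nM, two values within the usual scatter of each other. Compound 3 (`COc1ccc2nc(-c3ccc(N/C=C\C(=O)c4cc(OC)c(OC)c([N+](=O)[O-])c4)cc3)sc2c1`) gives 7610 nM, the lowest of the three numbers, and its gaps to compound 1 and to compound 2 both lie beyond the scatter.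

Compound 4 (`COc1ccc2nc(-c3ccc(N/C=C\C(=O)c4cc(OC)c(OC)c([N+](=O)[O-])c4)c(C)c3)sc2c1`) differs from compound 3 in one place, methyl in place of hydrogen on an aromatic carbon, ortho to a large group and meta to a 6-methoxy-1,3-benzothiazol-2-yl group.

Among the measured compounds shown here, no measured pair isolates this change. For the measured compounds named here, the only guide is indirect: compound 1 at 17000 nM and compound 2 at 17600 nM both carry this methyl, but each also differs from compound 3 elsewhere, so their higher numbers cannot be assigned to the methyl alone. Going by the values given here, with only three measured compounds, the evidence is thin and the range must stay wide.

The expected direction is upward, toward a weaker inhibitor, with the estimated step of a 1.8-fold higher number from compound 3 to compound 4 (0.26 log units; within the scatter) close to the edge of the scatter. For compound 4 the expected value in this assay is 14000 nM, with an estimated range of 6500 nM to 28000 nM.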

Compound 4, half-maximal inhibitory concentration: 5050 nM
Compound 4: middle estimate off by 2.8-fold (0.44 log units), on the high side, and the stated range ends above it.
By their numbers in this assay, from the lowest: compounds 4 and 3 (each within the scatter of the next); then compounds 1 and 2 (each within the scatter of the next).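

In this assay, among the compounds shown here, the first pair to isolate the methyl on the aromatic carbon, ortho to a large group and meta to a 6-methoxy-1,3-benzothiazol-2-yl group, gives a 1.5-fold lower number from compound 3 to compound 4 (0.18 log units; within the scatter), so hydrogen and methyl cannot be told apart at this position. With the methyl held constant, adding a methoxy group to an aromatic carbon gives a 3.5-fold lower number from compound 2 to compound 4 (0.54 log units; beyond the scatter) and nitro in place of methoxy on an aromatic carbon gives a 3.4-fold lower number from compound 1 to compound 4 (0.53 log units; beyond the scatter), so the higher numbers of compounds 1 and 2 go with these two changes and not with the methyl, which compound 4 also carries. No measurement at hand bears on the reason for any of these steps.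

Going by these compounds, this position is still described by a single pair in a single assay, so it remains open whether an ethyl group, a chlorine atom or a hydroxyl group there would also stay within the scatter of compound 3. On these data alone, it also remains open whether the methoxy and nitro steps would keep their size with hydrogen in place of the methyl.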